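Series notes: the fluoro step from compound 3 to compound 4

This account rests on a few compounds, and the source may have more. Where it says the series, first, only, none or still open, it means among the compounds named here.

Measured compounds in a functional assay on MDA-MB-468 cells (Homo sapiens) for antiproliferative activity, read by WST assay, with a stated time of 3 days; a higher number here means a weaker inhibitor, a lower number a stronger inhibitor:
compound 1, `N#Cc1cc(=O)[nH]c(=O)n1[C@@H]1O[C@H](CO)[C@@H](O)[C@H]1O`, gives > 50000 nM, a limit.
compound 2, `[N-]=[N+]=Nc1cc(=O)[nH]c(=O)n1[C@@H]1O[C@H](CO)[C@@H](O)[C@H]1O`, gives > 50000 nM, a limit.
compound 3, `Nc1cc(=O)[nH]c(=O)n1[C@@H]1O[C@H](CO)[C@@H](O)[C@H]1O`, gives > 50000 nM, a limit.

Compound 3 stands where the other two stand, at the limit, since (the limit of > 50000 nM in this assay, at which 3 of the 3 values shown sit). The measured steps a step that the two limits leave unreadable from compound 1 to compound 2, a step that the two limits leave unreadable from compound 1 to compound 3 and a step that the two limits leave unreadable from compound 2 to compound 3 have no readable size because of the limit of > 50000 nM in this assay, at which 3 of the 3 values shown sit, so none of them carries information on how a change at this core moves the read-out in this assay.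

Compound 4, `Nc1c(F)c(=O)[nH]c(=O)n1[C@@H]1O[C@H](CO)[C@@H](O)[C@H]1O`, differs from compound 3 by fluoro in place of hydrogen on an aromatic carbon. Going by the values given here, no measured step bears on this change. Compound 4 is therefore expected to stay at the limit, with an expected step of a number no higher from compound 3 to compound 4 (the limit leaves the size open). The estimate for compound 4 is 50000 nM, ranging from 20000 nM to 120000 nM.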

Compound 4, half-maximal inhibitory concentration: 2600 nM
Compound 4: middle estimate off by 19-fold (1.28 log units), on the high side, and the stated range ends above it.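

In this assay, going by these compounds alone, fluoro in place of hydrogen on the aromatic carbon ortho to the amino group gives an at least 19-fold lower number from compound 3 to compound 4 (1.28 log units; beyond the scatter), the only step at this core with a readable size. The steps among compound 1, compound 2 and compound 3 cannot be read, so this ring carbon is the one place shown where a single change moves the read-out. Only compound 4 stands clear of the limit: the limit of > 50000 nM in this assay, at which 3 of the 4 values shown sit.

On these data alone, whether chloro or methyl at this carbon also gives a readable value remains open. Also open, as far as these compounds go, is whether fluoro does so with a nitrile or azido group in place of the amino group.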